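A Carbamate in Place of the Urea: Expected Permeability

The compounds below may be only part of what the source reports. "The series", "measured", "known", "first", "only" and "open" are said of these compounds alone.

compound 1, `Cn1cncc1CN1CC(N(CC2CCN(C(=O)Nc3ccc(Br)cc3)CC2)S(=O)(=O)c2ccccn2)Cc2cc(C#N)ccc21`: 0.6 10^-6 cm/s
compound 2, `Cn1cncc1CN1CC(N(CC2CCN(C(=O)NC(C)(C)C)CC2)S(=O)(=O)c2ccccn2)Cc2cc(C#N)ccc21`: 0.6 10^-6 cm/s

In an ADME assay on Caco-2 cells (Homo sapiens) for permeability, in the apical to basolateral direction (a lower number here means that the compound crosses the layer more slowly, a higher number that the compound crosses the layer faster), compound 1 gives 0.6 10^-6 cm/s, and compound 2 gives 0.6 10^-6 cm/s, so compound 1 stands level with compound 2 at the digits shown. Compound 3 `Cn1cncc1CN1CC(N(CC2CCN(C(=O)OCc3ccccc3)CC2)S(=O)(=O)c2ccccn2)Cc2cc(C#N)ccc21` differs from compound 1 in one place: benzyloxy in place of (4-bromophenyl)amino on a carbonyl carbon. Among the measured compounds shown here, the one measured step that bears on this, no change at the digits printed from compound 1 to compound 2 (within the scatter), also exchanged the group on that carbonyl carbon and left the read-out unchanged within the scatter. Compound 3 is therefore expected to give 1 10^-6 cm/s, between 0.4 10^-6 cm/s and 2.5 10^-6 cm/s, an estimated step of a 1.7-fold higher number from compound 1 to compound 3 (0.22 log units; within the scatter) that stays within the scatter.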

Compound 3, apparent permeability: 1 10^-6 cm/s
The estimate for compound 3 equals the measured number at the digits printed, within the range that was stated.
By their numbers in this assay, from the lowest: compounds 1, 2 and 3 (each within the scatter of the next).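

With benzyloxy on the carbonyl carbon, this position now carries a group joined through oxygen instead of nitrogen, and this assay records a 1.7-fold higher number from compound 1 to compound 3 (0.22 log units; within the scatter) and a 1.7-fold higher number from compound 2 to compound 3 (0.22 log units; within the scatter) for that exchange. Replacing the hydrogen-bond donor of (4-bromophenyl)amino with the hydrogen-bond acceptor of benzyloxy therefore leaves the read-out within the scatter, as the earlier exchange of tert-butyl for 4-bromophenyl did. No available evidence explains this result. On these data alone, it remains open whether a dimethylamino group or a longer chain such as phenethyloxy on this carbonyl carbon would move the read-out beyond the scatter.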